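From compound 3 to compound 4: the chain on oxygen

The source may report more compounds than this note shows. Statements on the series, on what has been measured and on what is new or still open speak of the compounds shown alone.

Compound 1 `Cc1cc(=O)[nH]c(-c2cc(Oc3ccc(S(C)(=O)=O)cc3)cc(OC(C)C)c2)n1`: < 8 mL/min/kg, a limit.
Compound 2 `CC(C)Oc1cc(Oc2ccc(S(C)(=O)=O)cc2)cc(-c2ncc(Cl)c(=O)[nH]2)c1`: < 8 mL/min/kg, a limit.
Compound 3 `CCC(CC)Oc1cc(Oc2cnc(C(=O)N(C)C)nc2)cc(-c2nccc(=O)[nH]2)c1`: 22.4 mL/min/kg.

All three readings come from an ADME assay on microsomes from liver (Homo sapiens) for metabolic stability; a higher number here means faster removal of the compound, a lower number slower removal. Within the data shown here, compound 3 holds the only actual number in the set, since the other two readings are limits: the limit of < 8 mL/min/kg in this assay, at which 2 of the 3 values shown sit.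

Compound 4 `COC[C@H](C)Oc1cc(Oc2cnc(C(=O)N(C)C)nc2)cc(-c2nccc(=O)[nH]2)c1` keeps everything in compound 3 except the chain on the oxygen: 1-(methoxymethyl)ethyl in place of pentan-3-yl on an oxygen on an aromatic ring.

Among the measured compounds shown here, the single measured step is a step that the two limits leave unreadable from compound 1 to compound 2. That change lies on an aromatic carbon rather than on the oxygen, and it has no readable size, so it offers no scale for the present exchange. For the measured compounds named here, no measured step covers pentan-3-yl giving way to 1-(methoxymethyl)ethyl, and the expectation for this assay is therefore a matter of judgement. Starting from compound 3 at 22.4 mL/min/kg, a step beyond the scatter is not firmly expected, though a small lean towards slower removal is anticipated. The expected step is a 1.6-fold lower number from compound 3 to compound 4 (0.20 log units; within the scatter). For compound 4 the estimated clearance is 14 mL/min/kg, with an expected range of 8 mL/min/kg to 26 mL/min/kg.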

Compound 4, clearance in the Homo sapiens assay: < 8 mL/min/kg
Compound 4 was reported as a limit; the forecaster's own chance of this, stated with the estimate: 15%; middle value at least 1.7-fold (0.24 log units) away from the limit.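

In the Homo sapiens assay compound 4 is reported as a limit of the assay (< 8 mL/min/kg). Among these compounds, the exchange of pentan-3-yl for 1-(methoxymethyl)ethyl on an oxygen on an aromatic ring gives the first readable step, an at least 2.8-fold lower number from compound 3 to compound 4 (0.44 log units; beyond the scatter), so the chain on this oxygen is a place where a single exchange, at an unchanged count of heavy atoms, moves clearance beyond the scatter, and the printed size is only a minimum. In a physicochemical assay for solubility, in phosphate buffer, measured as kinetic solubility, with a stated time of 24 h, at pH 6.5 (a higher number here means a more soluble compound, a lower number a less soluble compound), the same exchange stays within the scatter: a 1.4-fold lower number from compound 3 to compound 4 (0.14 log units; within the scatter). In the physicochemical assay compound 3 reads (469000 nM) and compound 4 reads (342000 nM).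

Any further drop in clearance on this chain cannot be read from compound 4, which now shares the limit with most of the set: the limit of < 8 mL/min/kg in the Homo sapiens assay, at which 3 of the 4 values shown sit. Open questions are whether the oxygen inside the chain or the branching carries the step, which a 2-methoxyethyl chain or a chain ending in an amine on the same oxygen could test, and whether the other stereoisomer of 1-(methoxymethyl)ethyl reads the same.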